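Hydroxy on the Triazole Methyl of Compound 2

The compounds below may be only part of what the source reports. "The series", "measured", "known", "first", "only" and "open" are said of these compounds alone.

Measured compounds:
- compound 1, `Nc1cc(OCc2cc(-c3ccccc3)no2)c2nn[nH]c2n1`: 120 nM
- compound 2, `Cc1nn(-c2ccccc2)nc1COc1cc(N)nc2[nH]nnc12`: 27 nM

Within the data shown here, in an assay for inhibition of Myeloperoxidase (Homo sapiens), read by Amplex Red, with stated times of 10 min and 15 min (on this read-out higher numbers stand for weaker inhibition and lower numbers for stronger inhibition), compound 2 gives the lower of the two numbers so far; compound 1 sits at a markedly higher number, and that gap lies beyond the usual scatter of repeated measurements. Compound 3, `Nc1cc(OCc2nn(-c3ccccc3)nc2CO)c2nn[nH]c2n1`, has not yet been measured. It differs from compound 2 in one place: hydroxy in place of hydrogen on a saturated chain carbon bound to an aromatic carbon. Put another way, the methyl on the ring of compound 2 becomes a hydroxymethyl in compound 3. Among the measured compounds shown here, no pair of measured compounds that differ in this way is available, so there is nothing to read a step size from directly. My expectation is a modest change, if any, and the step of a 1.5-fold higher number from compound 2 to compound 3 (0.17 log units; within the scatter) is an estimate rather than a measurement. For compound 3 I expect a value near 40 nM, with a plausible range from 15 nM to 110 nM.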

Compound 3, half-maximal inhibitory concentration: 250 nM
Compound 3: the middle estimate sits 6.3-fold (0.80 log units) below what was measured; measured number outside the range, above it.
By their numbers in this assay, from the lowest: compound 2; then compound 1; then compound 3.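

In this assay, changing the methyl on the ring to a hydroxymethyl gives a 9.3-fold higher number from compound 2 to compound 3 (0.97 log units; beyond the scatter) and shows that this position responds strongly to the addition of a single oxygen atom. Among these compounds, this is the first step that can be read for one change in one place. Compound 1 and compound 2 differ in more than one place. Nothing available here bears on why the hydroxy has this effect.

The compounds shown leave open whether any added group at this place gives such a step or whether it is specific to the hydroxy, a question that an amine or a methoxy group in place of the hydroxy could address. They also leave open how a longer chain, such as hydroxyethyl, or a carboxylic acid would compare with compound 3.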